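Chloro in place of hydrogen on compound 2

This account rests on a few compounds, and the source may have more. Where it says the series, first, only, none or still open, it means among the compounds named here.

In a functional assay on HeLa cells (Homo sapiens) for antiproliferative activity, read by MTT assay, with a stated time of 48 h (a higher number here means a weaker inhibitor, a lower number a stronger inhibitor), compound 2 (`Oc1ccc2ccccc2c1C(Nc1nc2ccccc2s1)c1cn(-c2ccccc2)nc1-c1ccccc1`) gives 17300 nM and compound 1 (`Cc1cc2nc(NC(c3cn(-c4ccccc4)nc3-c3ccc([N+](=O)[O-])cc3)c3c(O)ccc4ccccc34)sc2cc1C`) gives 14700 nM (two values within the scatter of each other), so compound 2 stands level with compound 1. Compound 3 (`Oc1ccc2ccccc2c1C(Nc1nc2ccccc2s1)c1cn(-c2ccccc2)nc1-c1cccc(Cl)c1`) differs from compound 2 by chloro in place of hydrogen on an aromatic carbon, phenyl to 3-chlorophenyl (chloro in place of hydrogen on an aromatic carbon). Among the measured compounds shown here, no measured pair of compounds shows this change. The step expected in this assay is a 1.3-fold lower number from compound 2 to compound 3 (0.12 log units; within the scatter) and should stay within the scatter. Compound 3 is expected at 13000 nM (estimated range 5500 nM to 30000 nM).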

Compound 3, half-maximal inhibitory concentration: 6830 nM
Estimate against measurement, compound 3: 1.9-fold (0.28 log units) above; the range from low to high includes it.
By their numbers in this assay, from the lowest: compound 3; then compounds 1 and 2 (each within the scatter of the next).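

In this assay the change from phenyl to 3-chlorophenyl gives a 2.5-fold lower number from compound 2 to compound 3 (0.40 log units; beyond the scatter) and is the only single-place change among the compounds shown. It shows that this aromatic carbon, meta to a large group, is a place where chloro in place of hydrogen moves the number modestly but beyond the scatter. No measurement here offers a reason for the step. The compounds shown leave open whether fluoro, bromo or methoxy at this place would move the number the same way, and whether chloro elsewhere on this phenyl ring would do so.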